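Varying the ring-amine substituent: compound 2 to compound 4

The source may hold more compounds than are shown below. What is called first, only, known or untested is meant among the compounds shown, and "the series" means these compounds.

Measured compounds:
compound 1 `CC(C)(C)C[N+]1(C)CCc2c(sc(NC(=O)Nc3ccc(Cl)cc3)c2C(N)=O)C1` 290 nM
compound 2 `COCCCN1CCc2c(sc(NC(=O)Nc3ccc(Cl)cc3)c2C(N)=O)C1` 2400 nM
compound 3 `NC(=O)c1c(NC(=O)Nc2ccc(Cl)cc2)sc2c1CCN(CCCNC(=O)CCc1cccnc1)C2` 470 nM

In a functional assay (strain AB) with Danio rerio as the target, read by microscopy, with a stated time of 1 h (a higher number here means that more compound is needed for the effect, a lower number that less compound is needed), compound 2 gives 2400 nM, the highest of the three numbers. The nearest is compound 3, reached by a 5.1-fold lower number from compound 2 to compound 3 (0.71 log units; beyond the scatter). Among the measured compounds shown here, compound 1, at 290 nM, stands furthest from compound 2; no single-point step links these two, so their values can only be set side by side.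

Compound 4 `NC(=O)c1c(NC(=O)Nc2ccc(Cl)cc2)sc2c1CCN(CC1CCCCC1)C2` has not been measured. Relative to compound 2 the change is cyclohexyl in place of 2-methoxyethyl on a saturated chain carbon bound to an amine nitrogen in a ring. For the measured compounds named here, only one measured step bears on this, and indirectly: a 5.1-fold lower number from compound 2 to compound 3 (0.71 log units; beyond the scatter) alters the same chain, but three bonds along from the amine nitrogen rather than at the carbon bound to it, and brings in an amide rather than a ring. It shows that this chain accepts substantial change while the number falls modestly. Compound 1 carries a differently built substituent on the same amine nitrogen and gives 290 nM, also lower than compound 2. Going by the values given here, on that basis a modest decrease in the number is expected for compound 4, a 3.0-fold lower number from compound 2 to compound 4 (0.48 log units; beyond the scatter), with wide uncertainty since no measured step removes the acceptor alone. Compound 4 is estimated at 800 nM, within 250 nM to 2500 nM.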

Compound 4, half-maximal effective concentration: 1890 nM
Beside the measured number, compound 4's estimate is 2.4-fold (0.37 log units) below it, and the stated range covers the measured number.
By their numbers in this assay, from the lowest: compounds 1 and 3 (each within the scatter of the next); then compounds 4 and 2 (each within the scatter of the next).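

In this assay, cyclohexyl in place of 2-methoxyethyl on a saturated chain carbon bound to an amine nitrogen in a ring gives a 1.3-fold lower number from compound 2 to compound 4 (0.10 log units; within the scatter), so this exchange leaves the read-out unresolved from that of compound 2. Among the compounds shown here, the change takes out the hydrogen-bond acceptor of the leaving group and brings in a six-membered non-aromatic ring of carbon only, yet neither alteration registers, and a 5.1-fold lower number from compound 2 to compound 3 (0.71 log units; beyond the scatter) remains the only single-place change on this substituent that lies beyond the scatter. Nothing measured here gives a reason for this outcome.

Whether the step to compound 3 belongs to its amide or to its pyridin-3-yl ring stays open, as no compound shown holds either of these on the chain without the other. Also open, as far as these compounds go, is how a phenyl ring, a primary amine or a carboxylic acid would read in place of cyclohexyl on this chain carbon, and whether a longer chain between the ring amine nitrogen and the cyclohexyl would change the number.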